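Shortening One Sulfur-Linked Arm of Compound 2

The source may report more compounds than this note shows. Statements on the series, on what has been measured and on what is new or still open speak of the compounds shown alone.

Compound 2 `OCC#CCSc1cnc2ccccc2c1SCC#CCO` carries two 4-hydroxybut-2-yn-1-yl groups, each joined to the shared core through a sulfur. Going by the values given here, in a functional assay on CCRF-CEM cells (Homo sapiens) for cytotoxicity, read by sulforhodamine B assay, with a stated time of 72 h (on this read-out higher numbers stand for weaker inhibition and lower numbers for stronger inhibition), compound 2 gives 2.6 ug/mL, the lowest of the two numbers measured so far; its nearest neighbour is compound 1 `OCC#CCSc1cnc2ccccc2c1Cl`, which in this assay gives 4.1 ug/mL, and the step of a 1.6-fold lower number from compound 1 to compound 2 (0.20 log units; within the scatter) stays within the scatter. Compound 3 `CSc1c(SCC#CCO)cnc2ccccc12` differs from compound 2 by hydrogen in place of 3-hydroxyprop-1-yn-1-yl on a saturated chain carbon bound to a sulfur. Among the compounds with values here, only one measured step bears on this change, and it touches the same sulfur-bearing position from the other direction: installing the whole sulfur-linked arm in place of chlorine, a 1.6-fold lower number from compound 1 to compound 2 (0.20 log units; within the scatter), moved the number little. Cutting that arm back to a methyl is therefore expected to shift this assay by no more than the scatter, so the estimated step is a 1.3-fold higher number from compound 2 to compound 3 (0.13 log units; within the scatter). Compound 3 is thus expected to give about 3.5 ug/mL, with a range from 1.5 ug/mL to 8 ug/mL.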

Compound 3, concentration for 50% inhibition: 13.9 ug/mL
Compound 3: middle estimate off by 4.0-fold (0.60 log units), on the low side, and the stated range ends below it.
By their numbers in this assay, from the lowest: compounds 2 and 1 (each within the scatter of the next); then compound 3.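

In this assay, the arm at this sulfur does count: cutting 4-hydroxybut-2-yn-1-yl back to methyl gives a 5.3-fold higher number from compound 2 to compound 3 (0.73 log units; beyond the scatter), a step beyond the scatter, although replacing chlorine with the full arm had stayed within it. Methylsulfanyl also does not stand in for chloro on this aromatic carbon, with a 3.4-fold higher number from compound 1 to compound 3 (0.53 log units; beyond the scatter), again beyond the scatter, so the short group sets compound 3 apart from both compounds that carry chlorine or the full arm here. Nothing measured on these compounds accounts for this difference.

As far as these compounds go, what stays open is whether the triple bond, the hydroxyl or simply the length of the arm carries the step. A saturated butyl chain, or an amine in place of the hydroxyl at the chain end, would separate these readings.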